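Trimming a sulfur substituent on a triazole-isoxazoline scaffold

The compounds below may be only part of what the source reports. "The series", "measured", "known", "first", "only" and "open" are said of these compounds alone.

Compound 1 `O=C(Nn1c(COc2ccccc2C2=NOC(c3ccc(Cl)cc3Cl)C2)nnc1Sc1ccccc1)c1ccccc1` carries a phenyl on the sulfur of its shared core. In an ADME assay (MDM cells, Homo sapiens) for cytotoxicity, read by resazurin assay, with a stated time of 3 days (a lower number here means a stronger inhibitor, a higher number a weaker inhibitor), compound 1 is recorded as "not determined" (no result reported), so no single number places it on the scale. Within the data shown here, the only measured relative is compound 2 `CCSc1nnc(COc2ccccc2C2=NOC(c3ccc(Cl)cc3Cl)C2)n1NC(C)=O`, which bears an ethyl on that sulfur and a different acyl group on the ring nitrogen; in this assay compound 2 gives 9.7 ug/mL. Compound 3 `CSc1nnc(COc2ccccc2C2=NOC(c3ccc(Cl)cc3Cl)C2)n1NC(=O)c1ccccc1` keeps the benzamide of compound 1 but changes one group: methyl in place of phenyl on a sulfur. Among the measured compounds shown here, with no measured pair showing this exact change, the step from compound 1 to compound 3 in this assay is expected to be modest and could go either way, likely not beyond the scatter. Compound 3 is therefore estimated to fall near compound 2, at 12 ug/mL, within a range of 4 ug/mL to 40 ug/mL.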

Compound 3, half-maximal inhibitory concentration: 2.2 ug/mL
Beside the measured number, compound 3's estimate is 5.5-fold (0.74 log units) above it; the whole stated range lies above it.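

In this assay, among these compounds, compound 1 is recorded as "not determined" (no result reported), so no step from compound 1 to compound 3 can be read. What the compounds shown leave open is how phenylsulfanyl to methylsulfanyl alone shifts this read-out, and no evidence here bears on it.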